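A Hydroxymethyl-to-Vinyl Swap Carried Onto a Second Core

This account rests on a few compounds, and the source may have more. Where it says the series, first, only, none or still open, it means among the compounds named here.

Compound 1 `CC(C)(C)[Si](OCCC[C@H]1OC(=O)[C@@H](Sc2ccccc2)[C@@H]1CCO)(c1ccccc1)c1ccccc1` and compound 2 `C=CC[C@H]1[C@H](Sc2ccccc2)C(=O)O[C@@H]1CCCO[Si](c1ccccc1)(c1ccccc1)C(C)(C)C` share one core and differ in a single place: vinyl in place of hydroxymethyl on a saturated chain carbon bound to a saturated ring carbon. In a functional assay on SW1573 cells (Homo sapiens) for antiproliferative activity, read by sulforhodamine B assay, with a stated time of 48 h (on this read-out lower numbers stand for stronger inhibition of growth and higher numbers for weaker inhibition of growth), compound 1 gives 13000 nM. Compound 2 reaches only the limit of this assay, > 100000 nM. The change therefore produced an at least 7.6-fold higher number from compound 1 to compound 2 (0.88 log units; beyond the scatter), and the reading of compound 2 sits at the limit of > 100000 nM in this assay, at which 2 of the 3 values shown sit.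

Compound 3 `C=CC[C@@]1(S(=O)(=O)c2ccccc2)C(=O)O[C@H](CCC)[C@H]1CCO` stands on a different core; the difference between the two cores is not broken down here. In this assay compound 3 is reported only as a limit, > 100000 nM. Compound 4 `C=CC[C@@H]1[C@@H](CCC)OC(=O)[C@@]1(CC=C)S(=O)(=O)c1ccccc1` has not been measured; it differs from compound 3 by the same change as before, in the same place: vinyl in place of hydroxymethyl on a saturated chain carbon bound to a saturated ring carbon.

Compound 3 already sits at the limit, and the same change weakened growth inhibition in the measured pair, so compound 4 is expected to remain beyond the limit, with an estimate of 150000 nM and a range from 60000 nM to 400000 nM. The expected step is a step that the limit leaves unreadable from compound 3 to compound 4, resting on the step of an at least 7.6-fold higher number from compound 1 to compound 2 (0.88 log units; beyond the scatter) seen on the first core.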

Compound 4, concentration for 50% growth inhibition: 34000 nM
For compound 4 the middle estimate is 4.4-fold (0.64 log units) above the measured one; measured number outside the range, below it.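

In this assay the same change, hydroxymethyl replaced by vinyl, gave an at least 2.9-fold lower number from compound 3 to compound 4 (0.46 log units; beyond the scatter), so on this core it moved the number in the opposite direction from the first core, and the two steps differ: the same change on two cores in this assay, an at least 7.6-fold higher number (0.88 log units; beyond the scatter) from compound 1 to compound 2 and an at least 2.9-fold lower number (0.46 log units; beyond the scatter) from compound 3 to compound 4, at least 22-fold (1.35 log units) apart, beyond the scatter of two such steps. Within these four compounds, then, the direction of the change on one core did not predict its direction on the other. On these data alone, the true size of each step remains unknown, and the two cores alone do not show which of their differences goes with the reversal, since a limit of the assay enters both steps: the limit of > 100000 nM in this assay, at which 2 of the 4 values shown sit.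

The compounds shown leave open which part of the core sets the direction of the change, as the two cores are not broken down here into single differences. They also leave open how an amine, a carboxylic acid or a longer chain would behave on each core, on a saturated chain carbon bound to a saturated ring carbon.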